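Bromo for methoxy on the core of compound 1

The compounds below may be only part of what the source reports. "The series", "measured", "known", "first", "only" and "open" are said of these compounds alone.

Within the data shown here, in a functional assay on A549 cells (Homo sapiens) for inhibition, read by MTT assay, with a stated time of 24 h (on this read-out higher numbers stand for weaker inhibition of growth and lower numbers for stronger inhibition of growth), compound 1 `COc1ccc2c(c1)c(-c1nc3ccccc3n1C(=O)c1ccccc1OC)cn2C` gives 11900 nM, the higher of the two numbers so far, which makes it the weaker inhibitor of growth. Compound 2 `COc1ccc2c(c1)c(-c1nc3ccccc3n1C(=O)c1ccc(OC)c(OC)c1)cn2C` gives 2700 nM. Among the measured compounds shown here, the one measured step is a 4.4-fold lower number from compound 1 to compound 2 (0.64 log units; beyond the scatter), with 3,4-dimethoxyphenyl in place of 2-methoxyphenyl on a carbonyl carbon. Compound 3 `COc1ccccc1C(=O)n1c(-c2cn(C)c3ccc(Br)cc23)nc2ccccc21` keeps the 2-methoxyphenyl group and differs elsewhere: bromo in place of methoxy on an aromatic carbon. For the measured compounds named here, no measured step touches that place, so a 4.4-fold lower number from compound 1 to compound 2 (0.64 log units; beyond the scatter) shows only how far one change has moved this number, and it gives no direction for the new change. A smaller step is therefore expected in this assay, probably within the scatter. The estimate amounts to a 1.3-fold lower number from compound 1 to compound 3 (0.12 log units; within the scatter). For compound 3 the expected value is 9000 nM, with an estimated range from 3000 nM to 25000 nM.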

Compound 3, concentration for 50% growth inhibition: 12800 nM
Beside the measured number, compound 3's estimate is 1.4-fold (0.15 log units) below it, within the range that was stated.
By their numbers in this assay, from the lowest: compound 2; then compounds 1 and 3 (each within the scatter of the next).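

Putting bromo in place of methoxy on the core gives a 1.1-fold higher number from compound 1 to compound 3 (0.03 log units; within the scatter) in this assay and so the two numbers cannot be told apart. Among these compounds, this is the first look at this position, and it shows that here, with the 2-methoxyphenyl group kept on the carbonyl carbon, methoxy with its hydrogen-bond acceptor and bromo with none give the same result within the scatter. No measurement of any other kind is at hand to explain this result.

Going by these compounds, whether this position would respond to a group of quite another kind, such as an amine or a carboxylic acid, stays open. On these data alone, it is also open whether the same exchange would leave the number unmoved with the 3,4-dimethoxyphenyl group of compound 2 in place.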